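Adding a 4-acetylmorpholin-2-yl group to compound 2

The source may report more compounds than this note shows. Statements on the series, on what has been measured and on what is new or still open speak of the compounds shown alone.

Compound 1: `CN1CCC(CNS(=O)(=O)c2ccccc2Nc2cc(-c3ccc4ccn(C)c4c3)c3nccnc3c2)C1`, 35 ug/mL
Compound 2: `CNC(=O)c1ccncc1Nc1cc(-c2ccc3ccn(C)c3c2)c2nccnc2c1`, 4 ug/mL

In a physicochemical assay for solubility, read by spectrophotometry, measured as kinetic solubility, at pH 8, tested at 500 uM (a lower number here means a less soluble compound, a higher number a more soluble compound), compound 2 gives 4 ug/mL, the lowest of the two numbers; compound 1 gives 35 ug/mL, a gap beyond the scatter. Compound 3, `CC(=O)N1CCOC(CNC(=O)c2ccncc2Nc2cc(-c3ccc4ccn(C)c4c3)c3nccnc3c2)C1`, is not yet measured in this assay. It differs from compound 2 by 4-acetylmorpholin-2-yl in place of hydrogen on a saturated chain carbon bound to an amide-type nitrogen. Among the compounds with values here, with no comparable step measured, the account expects a modest rise in this assay for compound 3, a 2.5-fold higher number from compound 2 to compound 3 (0.40 log units; beyond the scatter), which may still sit within the scatter. Compound 3 is estimated at 10 ug/mL, within 3 ug/mL to 35 ug/mL.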

Compound 3, solubility: 268 ug/mL
Compound 3: the middle estimate sits 27-fold (1.43 log units) below what was measured; the whole stated range lies below it.
By their numbers in this assay, from the lowest: compound 2; then compound 1; then compound 3.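

In this assay, the place on a saturated chain carbon bound to an amide-type nitrogen takes a far larger group than hydrogen, and 4-acetylmorpholin-2-yl there gives a 67-fold higher number from compound 2 to compound 3 (1.83 log units; beyond the scatter). This large step is the first measured at this place, so the number at this position is shown to move strongly with what sits on that carbon. On these data alone, whether a morpholin-2-yl with a free ring amine, without the acetyl, or a simple longer chain would give a similar step remains open. No measurement shown accounts for the size of this step.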